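Swapping methoxy for tert-butyl on the aryl amine of compound 3

The source may report more compounds than this note shows. Statements on the series, on what has been measured and on what is new or still open speak of the compounds shown alone.

Compound 1: `CCCCCc1ccc(Nc2ccc3c(c2)C(=O)N(C2CCC(=O)NC2=O)C3=O)cc1` — 12%
Compound 2: `Cc1ccc(Nc2ccc3c(c2)C(=O)N(C2CCC(=O)NC2=O)C3=O)cc1` — 5%
Compound 3: `COc1ccc(Nc2ccc3c(c2)C(=O)N(C2CCC(=O)NC2=O)C3=O)cc1` — 29%

Three compounds sharing one core and differing only in the group on the outer aromatic ring have been tested in an assay on FRT-Jurkat cells for inhibition of nuclear factor NF-kappa-B complex (Homo sapiens), read by flow cytometry, with a stated time of 24 h, tested at 10 uM; on this read-out lower numbers stand for less inhibition and higher numbers for more inhibition at the one concentration tested (going by the name of the read-out). Compound 3 stands highest of the three; its nearest neighbour is compound 1, and the steps from both compound 1 and compound 2 up to compound 3 lie beyond the scatter, so its lead is real rather than noise. The step from compound 1 to compound 2 is within the scatter, so those two cannot be ordered.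

Compound 4, `CC(C)(C)c1ccc(Nc2ccc3c(c2)C(=O)N(C2CCC(=O)NC2=O)C3=O)cc1`, has not yet been measured. It differs from compound 3 in one place: tert-butyl in place of methoxy on an aromatic carbon.

Among the compounds with values here, two measured steps bear on this change. a number 17 percentage points higher from compound 1 to compound 3 (beyond the scatter) and a number 24 percentage points higher from compound 2 to compound 3 (beyond the scatter) both show that putting methoxy in place of an alkyl group raised inhibition by a modest amount. Compound 4 reverses that, replacing methoxy with an alkyl group, so a modest fall in this assay is expected, of a size like a number 19 percentage points lower from compound 3 to compound 4 (beyond the scatter). Compound 4 is therefore estimated at 10%, with a likely range from -5% to 25%.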

Compound 4, a percentage reported as inhibition, at one concentration (the size of the read-out at that concentration, not a potency): 17%
For compound 4 the middle estimate is 7 percentage points below the measured one; measured number inside the range.
By their numbers in this assay, from the lowest: compounds 2, 1 and 4 (each within the scatter of the next, the first and the last beyond it); then compound 3.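

In this assay a third alkyl group at this place on the outer ring, now a branched one, also stays short of methoxy, with a number 12 percentage points lower from compound 3 to compound 4 (beyond the scatter) and so with methoxy still ahead of every alkyl group shown. The alkyl groups are not all interchangeable either: tert-butyl in place of methyl gives a number 12 percentage points higher from compound 2 to compound 4 (beyond the scatter) even though methyl and pentyl could not be ordered, while tert-butyl in place of pentyl gives a number 5 percentage points higher from compound 1 to compound 4 (within the scatter) and leaves those two unordered as well, so only the two ends of the alkyl series are separated. Nothing in the data shown gives a reason for these differences.

Methoxy is the only group here that joins the ring through oxygen, so it remains open whether its lead extends to ethoxy, to a hydroxyl group or to a different kind of group, such as an amine or a chlorine atom. All these numbers also come from a single concentration, so they leave open whether the same order would hold across a full concentration series.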